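Replacing the aryl amide with a sulfonylmethyl group

This account rests on a few compounds, and the source may have more. Where it says the series, first, only, none or still open, it means among the compounds named here.

Measured compounds in a functional assay on HEK293 cells for agonist activity at Glucose-dependent insulinotropic receptor (Homo sapiens), read by cAMP accumulation, with a stated time of 30 min; a higher number here means a larger maximal response, a lower number a smaller maximal response:
Compound 1, `CC(O[C@H]1CC[C@]2(CC1)COC(C)(C)C2)c1nc(-c2ccc(S(C)(=O)=O)c(F)c2)no1`, gives 109%.
Compound 2, `CC1(C)C[C@]2(CC[C@H](OCc3nc(-c4ccc(S(C)(=O)=O)c(F)c4)no3)CC2)CO1`, gives 103%.
Compound 3, `CC(O[C@H]1CC[C@]2(CC1)COC(C)(C)C2)c1nc(-c2ccc(C(=O)N(C)C)c(F)c2)no1`, gives 86%.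

Compound 3 stands lowest of the three in this assay, with compound 2 nearest and compound 1 furthest from it, both beyond the scatter. The new compound 4, `CC(O[C@H]1CC[C@]2(CC1)COC(C)(C)C2)c1nc(-c2ccc(CS(C)(=O)=O)c(F)c2)no1`, differs from compound 3 in one place: (methylsulfonyl)methyl in place of dimethylcarbamoyl on an aromatic carbon.

Within the data shown here, two measured steps bear on this change. The step of a number 6 percentage points lower from compound 1 to compound 2 (within the scatter) shows that trimming the side chain on the shared core leaves the maximal response unchanged. The step of a number 23 percentage points lower from compound 1 to compound 3 (beyond the scatter) shows that exchanging methylsulfonyl for dimethylcarbamoyl on the aromatic carbon costs a modest amount of response. Compound 4 carries (methylsulfonyl)methyl, which is closer to the methylsulfonyl of compound 1 than to the dimethylcarbamoyl of compound 3. Because the step of a number 23 percentage points lower from compound 1 to compound 3 (beyond the scatter) was a modest loss, its partial reversal is expected to give compound 4 a modest gain, estimated as a number 14 percentage points higher from compound 3 to compound 4 (beyond the scatter). Compound 4 is thus expected to reach about 100% in this assay, within a range from 85% to 115%.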

Compound 4, largest response reached (reported as percent of maximum), in percent of the reference or control that the assay uses: 130%
Compound 4: the middle estimate sits 30 percentage points below what was measured; the whole stated range lies below it.
By their numbers in this assay, from the lowest: compound 3; then compounds 2 and 1 (each within the scatter of the next); then compound 4.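

At this position, on the aromatic carbon ortho to a fluoro group, this assay shows the exchange of dimethylcarbamoyl for (methylsulfonyl)methyl as a step of a number 44 percentage points higher from compound 3 to compound 4 (beyond the scatter). The comparison with methylsulfonyl gives a step of a number 21 percentage points higher from compound 1 to compound 4 (beyond the scatter), so the new group does more than restore the response seen with methylsulfonyl, and two sulfonyl-bearing groups of different length are separated at this position by more than the scatter. Nothing available explains this difference between the groups.

The compounds shown leave open whether a longer chain, such as 2-(methylsulfonyl)ethyl, would raise the maximal response further or lower it, and whether an aminomethyl group would behave like (methylsulfonyl)methyl here. They also leave open whether the same gain would appear on the core of compound 2, which has hydrogen in place of the chain methyl.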